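A few compounds are considered here, and "the series" means these few. Any claim that something is new, unique, unknown or untested is made for them only; others in the source may bear on it.

Compound 1 `CCN(CC)CCNC(=O)C1CC(C(CC)(CC)c2ccc(C#CC(C)(C)O)c(C)c2)=CN1CC` gave 56.3% in an assay on isolated protein for binding affinity to vitamin D3 receptor (Homo sapiens), read by fluorescence polarization, tested at 1 uM; on this read-out lower numbers stand for less inhibition and higher numbers for more inhibition at the one concentration tested (going by the name of the read-out); compound 2 `CCN(CC)CCNC(=O)C1CC(C(CC)(CC)c2ccc(C#CC(C)(O)CC)c(C)c2)=CN1CC` gave 59.2%.

Among the measured compounds shown here, compound 2 stands at one of only two numbers measured, and the single measured step, a number 2.9 percentage points higher from compound 1 to compound 2 (within the scatter), did not move the read-out beyond the scatter. Compound 3 `CCCC(O)(C#Cc1ccc(C(CC)(CC)C2=CN(CC)C(C(=O)NCCN(CC)CC)C2)cc1C)CCC` carries the change (a group of 8 heavy atoms (7 carbon, 1 oxygen; no ring) in place of a group of 5 heavy atoms (4 carbon, 1 oxygen; no ring), on a triple-bonded carbon). Since that earlier step enlarged the same group and left the read-out essentially unchanged, the further enlargement in compound 3 is expected to bring no step beyond the scatter, as a number 1.2 percentage points lower from compound 2 to compound 3 (within the scatter). Compound 3 is therefore estimated at 58%, within 42% to 72%.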

Compound 3, a percentage reported as inhibition, at one concentration (the size of the read-out at that concentration, not a potency): 51.1%
Compound 3: middle estimate off by 6.9 percentage points, on the high side; measured number inside the range.
By their numbers in this assay, from the lowest: compounds 3, 1 and 2 (each within the scatter of the next).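

In this assay the group of 8 heavy atoms on the triple-bonded carbon gave a number 8.1 percentage points lower from compound 2 to compound 3 (within the scatter) and a number 5.2 percentage points lower from compound 1 to compound 3 (within the scatter) and so stayed within the scatter of both smaller groups. This position therefore accepts a group of this size, with the same hydrogen-bond donor and acceptor counts, without a step beyond the scatter in this read-out. Nothing available explains this result.

The compounds shown leave open whether a group with an amine or a carboxylic acid in place of the hydroxyl would hold the read-out on this triple-bonded carbon. They also leave open whether still longer chains on the same carbon would do so.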